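A Methyl Group Moves Around the Anilide Ring

The compounds below may be only part of what the source reports. "The series", "measured", "known", "first", "only" and "open" are said of these compounds alone.

Compound 1 `O=C(CSC(=S)N[C@H]1CCOC1=O)Nc1ccccc1F` shares its core with compound 2 `O=C(CSC(=S)N[C@H]1CCOC1=O)Nc1ccc(Br)cc1`, compound 3 `Cc1cccc(NC(=O)CSC(=S)N[C@H]2CCOC2=O)c1` and the not yet measured compound 4 `Cc1ccc(NC(=O)CSC(=S)N[C@H]2CCOC2=O)cc1`. In a functional assay on EC9706 cells (Homo sapiens) for cytotoxicity, read by MTT assay, with a stated time of 72 h (on this read-out lower numbers stand for stronger inhibition and higher numbers for weaker inhibition), compound 1 reaches only a limit, > 128000 nM. Compound 3 likewise stops at a limit, > 128000 nM. Compound 2 alone yields a number, 67400 nM. The change from compound 1 to compound 4 is 4-methylphenyl in place of 2-fluorophenyl on an amide-type nitrogen. Within the data shown here, the steps that bear on it are an at least 1.8-fold lower number from compound 1 to compound 2 (0.27 log units; that floor lies within the scatter) and an at least 1.8-fold higher number from compound 2 to compound 3 (0.27 log units; that floor lies within the scatter), whereas a step that the two limits leave unreadable from compound 1 to compound 3. Because (the limit of > 128000 nM in this assay, at which 2 of the 3 values shown sit), the step to compound 4 is expected to be an at least 1.1-fold lower number from compound 1 to compound 4 (0.06 log units; that floor lies within the scatter), which in this assay would not rise above the scatter. Compound 4 is therefore expected near 110000 nM, within 50000 nM to 250000 nM, with a real chance that only a limit is reported.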

Compound 4, half-maximal inhibitory concentration: 93900 nM
Compound 4: the middle estimate sits 1.2-fold (0.07 log units) above what was measured; the range from low to high includes it.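

In this assay, 4-methylphenyl on the amide-type nitrogen gives a readable number, yet the steps to it stay small: an at least 1.3-fold lower number from compound 1 to compound 4 (0.13 log units; that floor lies within the scatter) and an at least 1.3-fold lower number from compound 3 to compound 4 (0.13 log units; that floor lies within the scatter). Methyl and bromo are not told apart here, with a 1.4-fold higher number from compound 2 to compound 4 (0.14 log units; within the scatter). Compound 1 and compound 3 remain the two compounds at a limit: the limit of > 128000 nM in this assay, at which 2 of the 4 values shown sit.

Going by these compounds, what an amine or a carboxylic acid on the phenyl ring would give stays open. On these data alone, the true size of the steps from compound 1 and compound 3 also stays open, as only their floors can be read.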